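Cytotoxicity of a Quinolinone-Type Amine Series on Canine Kidney Cells

This account rests on a few compounds, and the source may have more. Where it says the series, first, only, none or still open, it means among the compounds named here.

Measured compounds:
- compound 1 `CCc1ccc2[nH]c(=O)c(CN(Cc3ccc(C(C)(C)C)cc3)[C@H](C)c3ccc(F)cc3)cc2c1`: > 5000 nM
- compound 2 `CCc1ccc2[nH]c(=O)c(CN(Cc3ccc(C(C)(C)C)cc3)C(C)c3ccc(OC(F)F)cc3)cc2c1`: > 5000 nM
- compound 3 `COc1ccc(C(C)N(Cc2ccc(C(C)(C)C)cc2)Cc2cc3cc(C)ccc3[nH]c2=O)cc1Cl`: > 10000 nM

The three measured compounds share a common core and were tested in a toxicity assay on MDCK cells (Canis lupus familiaris) for cytotoxicity, read by crystal violet staining, with a stated time of 48 h; on this read-out lower numbers stand for higher toxicity in this test and higher numbers for lower toxicity in this test. For compound 1 the result > 5000 nM is a limit of the test rather than a number. For compound 2 the result > 5000 nM is likewise a limit. The step that the two limits leave unreadable from compound 1 to compound 2 therefore cannot be read in size. For compound 3 the result > 10000 nM is again a limit, so its standing is known only as a range: no cytotoxicity was detected within the tested concentrations. In summary, the limit of > 5000 nM in this assay, at which 2 of the 3 values shown sit, and (the limit of > 10000 nM in this assay, at which 1 of the 3 values shown sits); none of the three values is an exact number.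

Compound 4 `CCc1ccc2[nH]c(=O)c(CN(Cc3ccc(C(C)(C)C)cc3)C(C)c3ccc(OC)c(Cl)c3)cc2c1` is not yet measured in this assay. It differs from compound 3 by methyl in place of hydrogen on a saturated chain carbon bound to an aromatic carbon. Among the measured compounds shown here, no measured step in this set bears directly on this change, and every step available is hidden behind limits. Since compound 3 showed no measurable toxicity at > 10000 nM, compound 4 is expected to behave the same way, giving a step that the limit leaves unreadable from compound 3 to compound 4 that is not expected to exceed the usual scatter. The estimate for compound 4 is 15000 nM, with a range from 5000 nM to 50000 nM, and most likely the assay again reports only a limit.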

Compound 4, half-maximal cytotoxic concentration: > 10000 nM
Compound 4: only a limit was reported; the forecaster's own chance of this, stated with the estimate: 85%; the middle value does not contradict the limit.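

Compound 4 gives [ > 10000 nM ], a limit and not a number. Its steps from compound 1, compound 2 and compound 3 each join two limits, and none can be read in size. The compounds shown leave open at what concentration any of them becomes toxic to the cells, and whether any of these structural changes alters that concentration.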